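The source may report more compounds than this note shows. Statements on the series, on what has been measured and on what is new or still open speak of the compounds shown alone.

Measured in a functional assay on MCF7 cells (Homo sapiens) for inhibition, read by MTT assay, with a stated time of 48 h; a higher number here means a weaker inhibitor, a lower number a stronger inhibitor:

Compound 1 `COc1cc(/C=C2\SC(=O)N(CCNC(=O)Nc3c(C)n(C)n(-c4ccccc4)c3=O)C2=O)cc(OC)c1OC`: 7580 nM
Compound 2 `Cc1ccc(/C=C2\SC(=O)N(CC(=O)Nc3c(C)n(C)n(-c4ccccc4)c3=O)C2=O)cc1`: 65500 nM

Of these two compounds, compound 2 carries the higher number at 65500 nM and is the weaker inhibitor. Compound 1 stands at 7580 nM. The gap between these two compounds lies beyond the usual scatter. Compound 3 `Cc1cc(C)c(/C=C2\SC(=O)N(CC(=O)Nc3c(C)n(C)n(-c4ccccc4)c3=O)C2=O)c(C)c1` has not yet been measured. It keeps the rest of compound 2 and changes one group: 2,4,6-trimethylphenyl in place of 4-methylphenyl on a double-bonded chain carbon bound to a double-bonded ring carbon. The new group is 2,4,6-trimethylphenyl in place of 4-methylphenyl on a double-bonded chain carbon bound to a double-bonded ring carbon. Within the data shown here, no pair of measured compounds shows what such a change does, so the expectation is loose: a small step toward a lower number in this assay, not clearly beyond the scatter. The expected change is a 1.5-fold lower number from compound 2 to compound 3 (0.16 log units; within the scatter). Compound 3 is estimated at 45000 nM, with an expected range of 13000 nM to 130000 nM.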

Compound 3, half-maximal inhibitory concentration: 71100 nM
Compound 3: the middle estimate sits 1.6-fold (0.20 log units) below what was measured; measured number inside the range.
By their numbers in this assay, from the lowest: compound 1; then compounds 2 and 3 (each within the scatter of the next).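

In this assay, among these compounds, the first pair that differs in one place gives a 1.1-fold higher number from compound 2 to compound 3 (0.04 log units; within the scatter), so 2,4,6-trimethylphenyl and 4-methylphenyl on a double-bonded chain carbon bound to a double-bonded ring carbon cannot be told apart. Adding to the 7 carbon atoms of 4-methylphenyl to reach the 9 of 2,4,6-trimethylphenyl therefore brings no readable gain or loss at this place, at least for this pair. No measurement at hand offers an explanation for this result.

Going by these compounds, whether a different kind of group at this place, such as a 4-carboxyphenyl or a pyridine ring, would move the number remains open. Compound 1 differs from compound 2 in more than one place, so the compounds shown cannot tie its lower number to any single change.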